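Moving the Pyridine Nitrogen in Compound 2

This account rests on a few compounds, and the source may have more. Where it says the series, first, only, none or still open, it means among the compounds named here.

Measured in a physicochemical assay for solubility, at pH 5; a lower number here means a less soluble compound, a higher number a more soluble compound:
- compound 1 `O=C(Nc1ncc(Cc2ccncc2)s1)C1CCCCC1`: 1190 ug/mL
- compound 2 `O=C(CCC1CCCCC1)Nc1ncc(Cc2ccccn2)s1`: 60 ug/mL
- compound 3 `O=C(CCC1CCCCC1)Nc1ncc(Cc2ccnc3ccccc23)s1`: 5 ug/mL

Among these three compounds, compound 2 stands in the middle with 60 ug/mL. Compound 3 reads lower and compound 1 reads higher, and both gaps lie beyond the scatter.

The next compound is compound 4 `O=C(CCC1CCCCC1)Nc1ncc(Cc2ccncc2)s1`, which has not yet been measured. It differs from compound 2 by one exchange: pyridin-4-yl in place of pyridin-2-yl on a saturated chain carbon bound to an aromatic carbon. The same difference can be read as (pyridin-4-yl)methyl in place of (pyridin-2-yl)methyl. Within the data shown here, no pair of measured compounds differs in one place, so the data give no direct measure of this exchange.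

Compound 1 also carries pyridin-4-yl and gives 1190 ug/mL, but it differs from compound 2 elsewhere as well, so it offers only weak support for a rise. The exchange keeps the counted atoms the same, and only a small upward move in this assay is expected. The expected change is a 1.8-fold higher number from compound 2 to compound 4 (0.26 log units; within the scatter), at about the edge of the scatter. The estimated value for compound 4 is 110 ug/mL, with an expected range from 35 ug/mL to 350 ug/mL.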

Compound 4, solubility: 140 ug/mL
Beside the measured number, compound 4's estimate is 1.3-fold (0.10 log units) below it, within the range that was stated.
By their numbers in this assay, from the lowest: compound 3; then compound 2; then compound 4; then compound 1.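

With the chain and the shared core unchanged, the effect of exchanging one pyridine attachment for the other now has a measured size: in this assay pyridin-4-yl in place of pyridin-2-yl gives a 2.3-fold higher number from compound 2 to compound 4 (0.37 log units; beyond the scatter) and so marks a modest step. This is the first pair among the compounds shown that differs in one place, and it shows that the readout responds at the saturated chain carbon bound to an aromatic carbon even though the two groups have the same atoms and the same counts of hydrogen-bond donors and acceptors. No measurement shown bears on what lies behind this step.

The compounds shown leave open where pyridin-3-yl would fall in relation to pyridin-2-yl and pyridin-4-yl at this place, and whether a methyl or methoxy group on the pyridine ring would alter the reading. They also leave open whether the same exchange would give a step of similar size with a longer chain, as a single pair cannot establish a pattern.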